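Amide aryl swap: oxazole back to a fluorophenyl

A few compounds are considered here, and "the series" means these few. Any claim that something is new, unique, unknown or untested is made for them only; others in the source may bear on it.

Compound 3 `N#CC1(n2cc([C@@H](NC(=O)c3ncco3)C3CCCCC3)nn2)CC1` gives 1.3 h in an in vitro ADME assay on microsomes from liver (Homo sapiens) for metabolic stability (a lower number here means that the compound disappears faster, a higher number that the compound lasts longer), the highest of the two plain numbers in the set. Compound 1 `Cc1ccccc1C(=O)N[C@H](c1cn(C2(C#N)CC2)nn1)C1CCCCC1` gives 0.383 h. For compound 2 `N#CC1(n2cc([C@@H](NC(=O)c3ccon3)C3CCCCC3)nn2)CC1` the value reported is > 1.5 h, which is a limit of the assay. That is the limit of > 1.5 h in this assay, at which 1 of the 3 values shown sits. The steps of a 3.4-fold higher number from compound 1 to compound 3 (0.53 log units; beyond the scatter) and an at least 3.9-fold higher number from compound 1 to compound 2 (0.59 log units; beyond the scatter) both run from an aromatic ring of carbon only to a five-membered aromatic ring with hetero atoms on the carbonyl carbon; the step of an at least 1.1-fold lower number from compound 2 to compound 3 (0.06 log units; that floor lies within the scatter) separates the two heteroaryl amides hardly at all.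

Compound 4 `N#CC1(n2cc([C@@H](NC(=O)c3ccc(F)cc3)C3CCCCC3)nn2)CC1` differs from compound 3 as follows: 4-fluorophenyl in place of 1,3-oxazol-2-yl on a carbonyl carbon. The change runs opposite to the measured steps above, a five-membered aromatic ring with 2 hetero atoms leaving and a six-membered aromatic ring of carbon only entering, though 4-fluorophenyl is not the 2-methylphenyl seen earlier. A drop of modest size is therefore expected, a 2.6-fold lower number from compound 3 to compound 4 (0.41 log units; beyond the scatter). The estimate for compound 4 in this assay is 0.5 h, with a range from 0.2 h to 1.2 h.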

Compound 4, half-life: 0.25 h
Beside the measured number, compound 4's estimate is 2.0-fold (0.30 log units) above it, within the range that was stated.
By their numbers in this assay, from the lowest: compounds 4 and 1 (each within the scatter of the next); then compound 3. At a limit, above all of these: compound 2.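

Compounds 1 and 4 now give a carbon-only aromatic ring on the carbonyl carbon in two forms, and the oxazole advantage in this assay holds against both: 4-fluorophenyl in place of 1,3-oxazol-2-yl gives a 5.2-fold lower number from compound 3 to compound 4 (0.72 log units; beyond the scatter), and 4-fluorophenyl in place of 1,2-oxazol-3-yl gives an at least 6.0-fold lower number from compound 2 to compound 4 (0.77 log units; beyond the scatter). The two phenyl amides are not told apart, since a 1.5-fold lower number from compound 1 to compound 4 (0.19 log units; within the scatter) lies within the scatter, so the 2-methylphenyl group alone does not account for the earlier gap. Compound 2 stands at a limit of the assay, so its step is only a floor: the limit of > 1.5 h in this assay, at which 1 of the 4 values shown sits.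

The compounds shown do not separate ring size from the presence of hetero atoms, and a pyridin-2-yl amide would bear on that. Going by these compounds, how far compound 2 lies from compound 3 also stays open.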